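The compounds below may be only part of what the source reports. "The series", "measured", "known", "first", "only" and "open" are said of these compounds alone.

Compound 1 `COc1ccc(Nc2[nH]c(C)nc3nccc2-3)cc1` and compound 2 `CCOc1ccc(Nc2[nH]c(C)nc3nccc2-3)cc1` share one core, while compound 3 `Cc1nc2nccc-2c(NC(C)C)[nH]1` and the unmeasured compound 4 `CCC(C)Nc1[nH]c(C)nc2nccc1-2` share another; the difference between the two cores is not broken down here. In a functional assay on the whole organism for inhibition, with Nicotiana tabacum as the target (a lower number here means a stronger inhibitor, a higher number a weaker inhibitor), compound 1 gives 661000000 nM, compound 2 gives 347000000 nM and compound 3 gives 550000000 nM. The change from compound 1 to compound 2 is methyl in place of hydrogen on a saturated chain carbon bound to an oxygen on an aromatic ring, and it brought a 1.9-fold lower number from compound 1 to compound 2 (0.28 log units; within the scatter). The change from compound 3 to compound 4 is methyl in place of hydrogen on a saturated chain carbon, two bonds along the chain from a nitrogen on an aromatic ring; it is the same kind of change, but the place differs, on a saturated chain carbon bound to an oxygen on an aromatic ring in the first pair and on a saturated chain carbon two bonds along the chain from a nitrogen on an aromatic ring in the second. For compound 4 the expected step is a 1.6-fold lower number from compound 3 to compound 4 (0.20 log units; within the scatter), resting on the earlier pair because a 1.9-fold lower number from compound 1 to compound 2 (0.28 log units; within the scatter) stayed within the scatter. Compound 4 is therefore estimated at 350000000 nM, between 150000000 nM and 900000000 nM.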

Compound 4, half-maximal inhibitory concentration: 174000000 nM
The estimate for compound 4 lay 2.0-fold (0.30 log units) above the measured number; the measured number falls inside the stated range.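

In this assay the added methyl gave a 3.2-fold lower number from compound 3 to compound 4 (0.50 log units; beyond the scatter) and this modest step lies beyond the scatter, whereas the step on the core of compound 1 stayed within it. Even so, the two steps cannot be told apart: the same change on two cores in this assay, a 1.9-fold lower number (0.28 log units; within the scatter) from compound 1 to compound 2 and a 3.2-fold lower number (0.50 log units; beyond the scatter) from compound 3 to compound 4, 1.7-fold (0.22 log units) apart, within the scatter of two such steps. This suggests that the change carried over between these two cores, even at a different place, but a single pair of steps does not show that its size would hold on other cores or at other places.

The compounds shown leave open what a longer chain than sec-butyl would do on the core of compound 3. They also leave open what a chain ending in an amine or a carboxylic acid would do there.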